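Benzyl in place of cyclohexyl: working notes

A few compounds are considered here, and "the series" means these few. Any claim that something is new, unique, unknown or untested is made for them only; others in the source may bear on it.

In an ADME assay on microsomes from liver (Homo sapiens) for metabolic stability (on this read-out lower numbers stand for a shorter-lived compound and higher numbers for a longer-lived compound), compound 1 (`Cc1cc(C(/C=C2\OC(=O)NC2=O)C(C)C)c(=O)[nH]c1-c1ccc2cccc(F)c2c1`) gives > 3 h as a limit of the assay and not a number. Among the compounds with values here, compound 2 (`O=C1NC(=O)/C(=C/C(c2ccc(-c3ccc4cccc(F)c4c3)[nH]c2=O)C2CCCCC2)O1`) gives 1.09 h and sits within the scatter of compound 3 (`CC(C)C(CC1NC(=O)NC1=O)c1ccc(-c2ccc3cccc(F)c3c2)[nH]c1=O`) at 1.59 h as the only other number. Compound 4 (`O=C1NC(=O)/C(=C/C(Cc2ccccc2)c2ccc(-c3ccc4cccc(F)c4c3)[nH]c2=O)O1`) has not yet been measured. It carries benzyl in place of cyclohexyl on a saturated chain carbon bound to an aromatic carbon and a double-bonded chain carbon. Within the data shown here, no measured pair isolates this change, and in this assay a step within the scatter is expected (a 1.1-fold lower number from compound 2 to compound 4 (0.04 log units; within the scatter)) with no firm direction. Compound 4 is expected at 1 h (estimated range 0.5 h to 2.2 h).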

Compound 4, half-life: 1.3 h
Beside the measured number, compound 4's estimate is 1.3-fold (0.11 log units) below it, within the range that was stated.
By their numbers in this assay, from the lowest: compounds 2, 4 and 3 (each within the scatter of the next). At a limit, above all of these: compound 1.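

In this assay, within the data shown here, this is the first pair that isolates the position: a 1.2-fold higher number from compound 2 to compound 4 (0.08 log units; within the scatter). In this one pair, benzyl and cyclohexyl on a saturated chain carbon bound to an aromatic carbon and a double-bonded chain carbon cannot be told apart, whether the six-membered ring is aromatic or non-aromatic. Compound 1 stays a limit of the assay and not a number: the limit of > 3 h in this assay, at which 1 of the 4 values shown sits.

On these data alone, whether an amine or a carboxylic acid at this position would give a step beyond the scatter remains open. The cause of any such step also remains open.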